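Ring nitrogen substituent in the fused thiophene carboxamide ureas

A few compounds are considered here, and "the series" means these few. Any claim that something is new, unique, unknown or untested is made for them only; others in the source may bear on it.

Three compounds of the shared core have numbers in a functional assay (strain AB) with Danio rerio as the target, read by microscopy, with a stated time of 1 h; a higher number here means that more compound is needed for the effect, a lower number that less compound is needed. Compound 1 `CCN1CCc2c(sc(NC(=S)Nc3ccc(Cl)cc3)c2C(N)=O)C1` gives 6570 nM. Compound 2 `NC(=O)c1c(NC(=O)Nc2ccc(Cl)cc2)sc2c1CCN(C1CCOCC1)C2` gives 2830 nM. Compound 3 `CCN1CCc2sc(NC(=O)Nc3ccc(Cl)cc3)c(C(N)=O)c2CC1` gives 5800 nM. Compound 2 thus gives the lowest of the three numbers; its gap to compound 3 is the nearer one and its gap to compound 1 the wider one, and both gaps lie beyond the scatter of repeated measurements. Compound 1 and compound 3 both carry an ethyl on the ring amine nitrogen, and both give higher numbers than compound 2 with its oxan-4-yl.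

Compound 4 `CCCN1CCc2c(sc(NC(=O)Nc3ccc(Cl)cc3)c2C(N)=O)C1` has not yet been measured in this assay. It differs from compound 2 in one place: propyl in place of oxan-4-yl on an amine nitrogen in a ring

For the measured compounds named here, no step between measured compounds isolates this change, so the expectation rests on the two ethyl-bearing compounds. Going from compound 2 to compound 4 an upward step is expected, a 1.8-fold higher number from compound 2 to compound 4 (0.25 log units; within the scatter), since the ethyl compounds 1 and 3 sit above compound 2 and propyl stands closer to ethyl than to oxan-4-yl. Compound 4 is therefore estimated at 5000 nM, with a range from 2500 nM to 10000 nM.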

Compound 4, half-maximal effective concentration: 3500 nM
Beside the measured number, compound 4's estimate is 1.4-fold (0.15 log units) above it; the range from low to high includes it.
By their numbers in this assay, from the lowest: compounds 2, 4, 3 and 1 (each within the scatter of the next, the first and the last beyond it).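

In this assay the one clean read at this position is a 1.2-fold higher number from compound 2 to compound 4 (0.09 log units; within the scatter), so on the amine nitrogen in the ring, a propyl chain with no ring and no hydrogen-bond acceptor stands level with oxan-4-yl. For this pair, neither the six-membered ring nor its oxygen is needed to keep the number in this range, and the gaps from compound 2 to compound 1 and compound 3 cannot be credited to the nitrogen substituent, since those two compounds also differ from it in a further place. No measurement of any property of these compounds bears on this result.

Still open, on these data alone, is whether the same holds for groups of other kinds on this nitrogen, such as a longer chain like hexyl, a benzyl, or a chain ending in a primary amine or a carboxylic acid. A single pair also cannot show whether this match between propyl and oxan-4-yl carries over to the thiourea of compound 1 or to the ring arrangement of compound 3.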